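Removing the methyl from the core: compound 2 to compound 4

The source may report more compounds than this note shows. Statements on the series, on what has been measured and on what is new or still open speak of the compounds shown alone.

Compound 1 `C=C1CC(Cn2cc(C)c(=O)[nH]c2=O)(c2ccc(-c3ccccc3)cc2)OC1=O`: 13500 nM
Compound 2 `C=C1CC(Cn2cc(C)c(=O)[nH]c2=O)(c2ccc(F)cc2)OC1=O`: 16200 nM
Compound 3 `C=C1CC(Cn2ccc(=O)[nH]c2=O)(c2ccc(-c3ccccc3)cc2)OC1=O`: 10500 nM

Of the compounds shown here, three sharing one core have been measured in a functional assay on SK-OV-3 cells (Homo sapiens) for inhibition; a lower number here means a stronger inhibitor of growth, a higher number a weaker inhibitor of growth. Compound 2 carries a fluoro group where compound 1 carries a phenyl group, and a 1.2-fold higher number from compound 1 to compound 2 (0.08 log units; within the scatter). Compound 3 differs from compound 1 only by a hydrogen in place of a methyl on the core, and a 1.3-fold lower number from compound 1 to compound 3 (0.11 log units; within the scatter). All three numbers lie within the scatter of one another, so compound 2 cannot be separated from compound 1 or compound 3 on these data.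

Compound 4 `C=C1CC(Cn2ccc(=O)[nH]c2=O)(c2ccc(F)cc2)OC1=O` has not been measured. It differs from compound 2 by hydrogen in place of methyl on an aromatic carbon. The same exchange has been seen once before, going from compound 1 to compound 3, where the step stayed within the scatter. The expected step in this assay is therefore a 1.3-fold lower number from compound 2 to compound 4 (0.11 log units; within the scatter), about the same small size and not beyond the scatter. For compound 4 the estimate is 12500 nM, with a range from 6000 nM to 28000 nM.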

Compound 4, concentration for 50% growth inhibition: 15100 nM
Compound 4: the middle estimate sits 1.2-fold (0.08 log units) below what was measured; the measured number falls inside the stated range.
By their numbers in this assay, from the lowest: compounds 3, 1, 4 and 2 (each within the scatter of the next).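

In this assay, the exchange of methyl for hydrogen on the core now has a second reading, with a 1.1-fold lower number from compound 2 to compound 4 (0.03 log units; within the scatter), and the two readings agree: the same change on two cores in this assay, a 1.3-fold lower number (0.11 log units; within the scatter) from compound 1 to compound 3 and a 1.1-fold lower number (0.03 log units; within the scatter) from compound 2 to compound 4, 1.2-fold (0.08 log units) apart, within the scatter of two such steps

The exchange of phenyl for fluoro also gains a second reading, on the core without the methyl, with a 1.4-fold higher number from compound 3 to compound 4 (0.16 log units; within the scatter), and again the two agree: the same change on two cores in this assay, a 1.2-fold higher number (0.08 log units; within the scatter) from compound 1 to compound 2 and a 1.4-fold higher number (0.16 log units; within the scatter) from compound 3 to compound 4, 1.2-fold (0.08 log units) apart, within the scatter of two such steps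

The four compounds thus test each change with the other group in both forms, and at this position on the six-membered aromatic ring with 2 nitrogen, methyl and hydrogen cannot be told apart whether phenyl or fluoro is present.

Methyl and hydrogen are the only groups shown at this position, so it remains open whether an amine, a carboxylic acid or a longer chain such as propyl would give a step beyond the scatter. No step among these compounds lies beyond the scatter, so they do not show which part of the structure governs growth inhibition.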